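From Butyl to Cyclopentyl on the Ring Nitrogen

The compounds below may be only part of what the source reports. "The series", "measured", "known", "first", "only" and "open" are said of these compounds alone.

Two compounds share one core and differ only in the group carried on an aromatic nitrogen. Compound 1 `CC(C)n1cnc2c(Nc3cccc(Cl)c3)nc(NCOCc3ccc(C(=O)Nc4ccccc4N)cc3)nc21` carries an isopropyl group there, and in a functional assay on HCT-116 cells (Homo sapiens) for antiproliferative activity, read by CCK-8 assay, with a stated time of 72 h, tested at 2 uM (on this read-out higher numbers stand for a stronger effect at the one concentration tested and lower numbers for a weaker effect), compound 1 gives 7.12%. Compound 2 `CCCCn1cnc2c(Nc3cccc(Cl)c3)nc(NCOCc3ccc(C(=O)Nc4ccccc4N)cc3)nc21` carries a butyl group at the same place, and in this assay compound 2 gives 58.9%. For the measured compounds named here, the single swap gave a number 51.8 percentage points higher from compound 1 to compound 2 (beyond the scatter), so compound 2 stands highest of the two numbers measured, clearly beyond the scatter from compound 1.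

Compound 3 `Nc1ccccc1NC(=O)c1ccc(COCNc2nc(Nc3cccc(Cl)c3)c3ncn(C4CCCC4)c3n2)cc1` has not yet been measured and differs from compound 2 in one place: cyclopentyl in place of butyl on an aromatic nitrogen. Going by the values given here, only one measured step touches this position, and it was large: a number 51.8 percentage points higher from compound 1 to compound 2 (beyond the scatter). That step shows the read-out responds strongly to what sits on this nitrogen, but it says nothing about a ring in place of an open chain. The step is therefore expected to be modest, a number 10.9 percentage points lower from compound 2 to compound 3 (beyond the scatter), with wide uncertainty. In this assay compound 3 is expected to give 48%, within a range from 15% to 80%.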

Compound 3, a percentage reported as inhibition, at one concentration (the size of the read-out at that concentration, not a potency): 29.2%
The estimate for compound 3 lay 18.8 percentage points above the measured number; measured number inside the range.
By their numbers in this assay, from the lowest: compound 1; then compound 3; then compound 2.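

In this assay, what matters on this nitrogen is more than the number of carbons: cyclopentyl in place of butyl gives a number 29.7 percentage points lower from compound 2 to compound 3 (beyond the scatter), even though the ring brings 5 carbon against 4 in the open chain. Cyclopentyl in place of isopropyl gives a number 22.1 percentage points higher from compound 1 to compound 3 (beyond the scatter), so the ring recovers part of what separates isopropyl from butyl without matching butyl, and the three groups now form an order with every step beyond the scatter: isopropyl lowest, cyclopentyl in the middle and butyl highest. Nothing available here explains why the groups fall in this order.

The compounds shown leave open whether a longer open chain such as hexyl would raise the number further or lower it, and whether a cyclohexyl ring would behave like cyclopentyl. They also leave open how a butyl chain ending in an amine or a carboxylic acid would compare, and whether this order, seen as a stronger or weaker effect at a single concentration in one cell line, would hold at other concentrations.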